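Aryl swap on a pentacyclic lactam-indole core: cytotoxicity notes

The source may hold more compounds than are shown below. What is called first, only, known or untested is meant among the compounds shown, and "the series" means these compounds.

Measured so far: compound 1 `O=c1oc2ccccc2c2nc3c(ccc4cc[nH]c43)c(-c3ccc(C(F)(F)F)cc3)c12`, 70700 nM; compound 2 `O=c1oc2ccccc2c2nc3c(ccc4cc[nH]c43)c(-c3ccccn3)c12`, 70700 nM.

In a functional assay on B16-F10 cells (Mus musculus) for cytotoxicity (on this read-out lower numbers stand for stronger inhibition and higher numbers for weaker inhibition), compound 1 gives 70700 nM and compound 2 gives 70700 nM, so compound 1 stands level with compound 2. Among the compounds with values here, the one measured step, no change at the digits printed from compound 1 to compound 2 (within the scatter), changes nothing beyond the scatter. Compound 3 `O=c1oc2ccccc2c2nc3c(ccc4cc[nH]c43)c(-c3ccc(Cl)cc3Cl)c12` differs from compound 1 by 2,4-dichlorophenyl in place of 4-(trifluoromethyl)phenyl on an aromatic carbon. Within the data shown here, no measured step covers this exact change; the only step available is a swap at the same place that left this assay unchanged, so no shift beyond the scatter is expected, no change at the digits printed from compound 1 to compound 3 (within the scatter). Compound 3 is estimated at 70700 nM, range 30000 nM to 160000 nM.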

Compound 3, half-maximal inhibitory concentration: 70700 nM
Beside the measured number, compound 3's estimate shows no gap at the digits printed; the range from low to high includes it.
By their numbers in this assay, from the lowest: compounds 1, 2 and 3 (each within the scatter of the next).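

In this assay the 2,4-dichlorophenyl group, a third aryl group on this aromatic carbon opposite the ring nitrogen, gives no change at the digits printed from compound 1 to compound 3 (within the scatter) and no change at the digits printed from compound 2 to compound 3 (within the scatter) on the shared core. The flat reading at this place thus extends from a single swap to three aryl groups, one of them carrying chlorine rather than fluorine. Nothing at hand accounts for this outcome.

Still open, from the compounds shown here alone, is whether a non-aryl group here, such as an aminomethyl group, a carboxylic acid or a longer alkyl chain, would shift the value. Also open, going by these compounds, is whether changes elsewhere on the shared core would do so.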